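A few compounds are considered here, and "the series" means these few. Any claim that something is new, unique, unknown or untested is made for them only; others in the source may bear on it.

Measured in an ADME assay on NL20 cells (Homo sapiens) for antiproliferative activity, read by MTT assay, with a stated time of 24 h; a higher number here means a weaker inhibitor, a lower number a stronger inhibitor:

Compound 1 `O=C(/C=C/c1ccc(O)cc1)NNC(=O)c1ccccc1`: 9750 nM
Compound 2 `COc1cc(/C=C/C(=O)NNC(=O)c2ccccc2)ccc1O`: 9550 nM
Compound 3 `COc1ccc(C(=O)NNC(=O)/C=C/c2ccc(O)c(OC)c2)cc1`: > 10000 nM, a limit and not a number

Compound 2 stands within the scatter of compound 1, and no measured number in this small set stands clear of it. The next compound, compound 4 `O=C(/C=C/c1ccc(O)c(O)c1)NNC(=O)c1ccccc1`, differs from compound 2 by hydrogen in place of methyl on an oxygen on an aromatic ring, or methoxy to hydroxy.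

Going by the values given here, two measured steps bear on this change, though neither is the same swap. The step of a 1.0-fold lower number from compound 1 to compound 2 (0.01 log units; within the scatter) brought in the methoxy that compound 4 gives up, and it stayed within the scatter. The other methoxy step, an at least 1.0-fold higher number from compound 2 to compound 3 (0.01 log units; that floor lies within the scatter), ends at a limit, and its floor also lies within the scatter. With neither step showing a measurable shift, no change beyond the scatter is expected. The expected step is a 1.1-fold lower number from compound 2 to compound 4 (0.05 log units; within the scatter). Compound 4 is estimated at 8500 nM, with an expected range from 4000 nM to 14000 nM.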

Compound 4, half-maximal inhibitory concentration: 8850 nM
Compound 4: the middle estimate sits 1.0-fold (0.02 log units) below what was measured; measured number inside the range.
By their numbers in this assay, from the lowest: compounds 4, 2 and 1 (each within the scatter of the next). At a limit, above all of these: compound 3.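

In this assay, replacing the methyl on an oxygen on an aromatic ring with hydrogen gives a 1.1-fold lower number from compound 2 to compound 4 (0.03 log units; within the scatter), so the methoxy to hydroxy change shows no measurable shift at this position. Swapping a hydrogen of the ring for a hydroxy gives a 1.1-fold lower number from compound 1 to compound 4 (0.04 log units; within the scatter), which means that hydrogen, methoxy and hydroxy at this place, in compound 1, compound 2 and compound 4, cannot be told apart by these numbers. Nothing measured here gives a reason for this flat result.

On these data alone, whether an amine, a carboxylic acid or a longer chain such as ethoxy at this place would move the number beyond the scatter remains open. As far as these compounds go, compound 3, with > 10000 nM, is a limit and not a number, so the size of its difference remains open too.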